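The source may report more compounds than this note shows. Statements on the series, on what has been measured and on what is new or still open speak of the compounds shown alone.

Compound 1 `COc1ccc(C(=O)/C=C/c2cc3ccccc3[nH]c2=O)cc1`: 1850 nM
Compound 2 `O=C(/C=C/c1cc2ccccc2[nH]c1=O)c1ccc(O)cc1`: 2470 nM

In a functional assay on LOX IMVI cells (Homo sapiens) for cytotoxicity, read by sulforhodamine B assay, with a stated time of 24 h (on this read-out lower numbers stand for stronger inhibition of growth and higher numbers for weaker inhibition of growth), compound 2 gives 2470 nM, and the step of a 1.3-fold higher number from compound 1 to compound 2 (0.13 log units; within the scatter) lies within the scatter, so the two measured compounds cannot be told apart. Compound 3 `O=C(/C=C/c1cc2ccccc2[nH]c1=O)c1ccc(Cl)cc1` differs from compound 2 by chloro in place of hydroxy on an aromatic carbon. Among the compounds with values here, no measured step exchanges hydroxy for chloro; the only step known, a 1.3-fold higher number from compound 1 to compound 2 (0.13 log units; within the scatter), is hydrogen in place of methyl on an oxygen on an aromatic ring and bears on this change only loosely. Compound 3 is therefore expected to stay near compound 2 in this assay, the estimated step being a 1.4-fold lower number from compound 2 to compound 3 (0.14 log units; within the scatter). The estimate for compound 3 is 1800 nM, with a range of 600 nM to 5500 nM.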

Compound 3, concentration for 50% growth inhibition: 3260 nM
Compound 3: the middle estimate sits 1.8-fold (0.26 log units) below what was measured; measured number inside the range.
By their numbers in this assay, from the lowest: compounds 1, 2 and 3 (each within the scatter of the next).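

In this assay the step of a 1.3-fold higher number from compound 2 to compound 3 (0.12 log units; within the scatter) lies within the scatter, so at this place on the aromatic ring, chloro, with no hydrogen-bond donor or acceptor, cannot be told apart from hydroxy. The step of a 1.8-fold higher number from compound 1 to compound 3 (0.25 log units; within the scatter) also lies within the scatter, which means that methoxy, hydroxy and chloro all read alike here. Nothing available explains this sameness. On these data alone, whether an amine, a carboxylic acid or a longer chain such as butoxy at this place would move the number beyond the scatter stays open. So does the effect of any change on the shared core.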